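Series notes: benzyloxy variation on the shared core

The source may report more compounds than this note shows. Statements on the series, on what has been measured and on what is new or still open speak of the compounds shown alone.

For the measured compounds named here, compound 2 `O=C(Nc1cccnc1)c1ccccc1OCc1cccc(F)c1` gives 1600 nM in an assay on lysate for inhibition of phosphatidylcholine:ceramide cholinephosphotransferase 2 (Homo sapiens), read by HPLC, with stated times of 30 min and 2 h (on this read-out lower numbers stand for stronger inhibition and higher numbers for weaker inhibition), the lowest of the two numbers so far; the nearest is compound 1 `N#Cc1ccccc1COc1ccccc1C(=O)Nc1cccnc1` with 31800 nM. Going by the values given here, the only step in hand is a 20-fold lower number from compound 1 to compound 2 (1.30 log units; beyond the scatter), which exchanges the aromatic group on the saturated chain carbon bound to an oxygen on the aromatic ring. Compound 3 `O=C(Nc1cccnc1)c1ccccc1OCc1c(F)cccc1Cl` changes that same group again: 2-chloro-6-fluorophenyl in place of 3-fluorophenyl on a saturated chain carbon bound to an oxygen on an aromatic ring. Among the compounds with values here, no step in this assay tests a 2-chloro-6-fluorophenyl, so the step from compound 1 to compound 2 bears on it only in showing that this position moves the number strongly. For compound 3 in this assay a modest drop in number is expected, a 2.7-fold lower number from compound 2 to compound 3 (0.43 log units; beyond the scatter), with wide uncertainty. The estimate for compound 3 is 600 nM, expected to fall between 150 nM and 2500 nM.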

Compound 3, half-maximal inhibitory concentration: 1500 nM
Beside the measured number, compound 3's estimate is 2.5-fold (0.40 log units) below it; the measured number falls inside the stated range.
By their numbers in this assay, from the lowest: compounds 3 and 2 (each within the scatter of the next); then compound 1.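

In this assay, 2-chloro-6-fluorophenyl in place of 3-fluorophenyl reads as a 1.1-fold lower number from compound 2 to compound 3 (0.03 log units; within the scatter), so at this position the two halogen-bearing phenyl groups cannot be told apart, although the entering group carries one more heavy atom, a chlorine. The same group set against the 2-cyanophenyl of compound 1 gives a 21-fold lower number from compound 1 to compound 3 (1.33 log units; beyond the scatter), so the large step seen earlier is not tied to the 3-fluorophenyl alone. No measured evidence accounts for either reading.

From the compounds shown here alone, it remains open how groups of another kind would read on this saturated chain carbon, such as a phenyl bearing an amine or a carboxylic acid. Also open, going by these compounds, is whether a longer chain in place of that single carbon would keep the number of compound 2 and compound 3.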